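Carbamoyl in place of cyano, ortho and meta cases

A few compounds are considered here, and "the series" means these few. Any claim that something is new, unique, unknown or untested is made for them only; others in the source may bear on it.

Three members of the series have been measured in a physicochemical assay for acid dissociation, using potentiometric titration. Compound 1 `CCCN1CCN(c2ccccc2C#N)CC1` gives 7.92. Compound 3 `CCCN1CCN(c2ccccc2C(N)=O)CC1` gives 8.14; the change from compound 1 to compound 3 is carbamoyl in place of cyano on an aromatic carbon, and it gives a number 0.22 log units higher from compound 1 to compound 3 (within the scatter). Compound 2 `CCCN1CCN(c2cccc(C#N)c2)CC1` shares its atoms with compound 1 but joins them differently; the difference between the two cores is not broken down here. In this assay compound 2 gives 7.67, which against compound 1 lies within the scatter, while compound 3 stands beyond the scatter above it.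

Compound 4 `CCCN1CCN(c2cccc(C(N)=O)c2)CC1` is not yet measured in this assay. Its change from compound 2 is carbamoyl in place of cyano on an aromatic carbon. Among the measured compounds shown here, this is the same kind of change as the one from compound 1 to compound 3, but not the same: there the carbamoyl sits ortho to a group of 9 heavy atoms, here it sits meta to a group of 9 heavy atoms. For the measured compounds named here, with only the one measured instance to lean on, the step is estimated to be a number 0.22 log units higher from compound 2 to compound 4 (within the scatter), because a number 0.22 log units higher from compound 1 to compound 3 (within the scatter) is the single observed case of this exchange. On that basis compound 4 is expected to give about 7.89 in this assay, with the likely range running from 7.6 to 8.2.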

Compound 4, acid dissociation constant: 7.76
Compound 4: the middle estimate sits 0.13 log units above what was measured, within the range that was stated.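

The exchange of cyano for carbamoyl on an aromatic carbon now reads a number 0.22 log units higher from compound 1 to compound 3 (within the scatter) and a number 0.09 log units higher from compound 2 to compound 4 (within the scatter) in this assay and so both instances lie within the scatter. Carried from the core of compound 1 to the core of compound 2, the exchange therefore stays inside the scatter each time, which supports treating it as a small step on these two cores, but neither step can be told apart from no shift at all, so no firm size or direction can be assigned to it, and two pairs say nothing about any other core. No measurement shown here bears on why the steps come out this way.

The compounds shown carry only cyano and carbamoyl at this place, so it remains open whether a carboxylic acid or an amine there would give a step beyond the scatter in this assay on either core. Also open, on these data alone, is whether a longer chain in place of the propyl chain would leave the cyano-to-carbamoyl step as small as it is in these two pairs.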